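The source may hold more compounds than are shown below. What is called first, only, known or untested is meant among the compounds shown, and "the series" means these compounds.

Of the compounds shown here, three sharing one core have been measured in an assay for inhibition of 15-hydroxyprostaglandin dehydrogenase [NAD(+)] (Homo sapiens), read by fluorescence and spectrophotometry; a higher number here means a weaker inhibitor, a lower number a stronger inhibitor. Compound 1 `CC(C)OCCOc1ccc(/C=C2\SC(=O)NC2=O)c(Cl)c1` gives 1050 nM, compound 2 `O=C1NC(=O)/C(=C/c2ccc(OCc3ccc([N+](=O)[O-])cc3)cc2Cl)S1` gives 4540 nM, and compound 3 `O=C1NC(=O)/C(=C/c2ccc(OC(=O)c3cccs3)c(Cl)c2)S1` gives 264 nM. Compound 3 thus shows the lowest number of the three, and its gap to each of the other two lies beyond the usual scatter, so it counts as the strongest inhibitor here. Compound 4 `O=C1NC(=O)/C(=C/c2ccc(OCC3CC4CCC3C4)c(Cl)c2)S1` has not yet been measured; it differs from compound 3 by a group of 8 heavy atoms (8 carbon; 2 five-membered non-aromatic rings of carbon only) in place of a group of 7 heavy atoms (5 carbon, 1 oxygen, 1 sulfur; one five-membered aromatic ring with 1 hetero atom), on an oxygen on an aromatic ring. Because compound 1 gives 1050 nM and compound 2 gives 4540 nM, both ethers sitting above the ester, the step of a 3.8-fold higher number from compound 3 to compound 4 (0.58 log units; beyond the scatter) is expected to go toward a higher number, beyond the scatter. Compound 4 is estimated at 1000 nM, within 300 nM to 3500 nM.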

Compound 4, half-maximal inhibitory concentration: 165 nM
Estimate against measurement, compound 4: 6.1-fold (0.78 log units) above; the whole stated range lies above it.
By their numbers in this assay, from the lowest: compounds 4 and 3 (each within the scatter of the next); then compound 1; then compound 2.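

At the oxygen on the aromatic ring, the step of a 1.6-fold lower number from compound 3 to compound 4 (0.20 log units; within the scatter) replaces the (thiophen-2-yl)carbonyl with an all-carbon group of 2 five-membered non-aromatic rings and leaves the inhibition indistinguishable. So, for this pair, neither an aromatic ring nor a carbonyl in this group is needed to keep inhibition at this level. No measured data offer a reason for this match. Still open, from the compounds shown here alone, is whether a group carrying an amine or a carboxylic acid at this oxygen would hold the same level. A small methyl group there is equally untested among the compounds shown.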